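The compounds below may be only part of what the source reports. "The series", "measured", "known", "first", "only" and "open" are said of these compounds alone.

Measured compounds in an assay on membranes from brain for binding affinity to Neuronal acetylcholine receptor; alpha4/beta2 (Rattus norvegicus); a higher number here means a weaker inhibitor, a lower number a stronger inhibitor:
- compound 1 `CN1CCC[C@H]1COc1cncc(-c2ccccc2)c1` gives 0.11 nM
- compound 2 `Cc1ccccc1-c1cncc(OC[C@@H]2CCCN2C)c1` gives 1.1 nM
- compound 3 `CN1CCC[C@H]1COc1cncc(-c2ccc(F)cc2)c1` gives 0.11 nM

Compound 3 stands level with compound 1 at the digits shown, the two together the lowest numbers of the three, and sits a 10-fold lower number from compound 2 to compound 3 (1.00 log units; beyond the scatter). The step of no change at the digits printed from compound 1 to compound 3 (within the scatter) shows that a fluoro on the distal ring adds nothing measurable, whereas a 10-fold higher number from compound 1 to compound 2 (1.00 log units; beyond the scatter) shows that a methyl on that ring costs a clear amount in this assay.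

Compound 4 `CN1CCC[C@H]1COc1cncc(-c2cccs2)c1` is not yet measured. The change is thiophen-2-yl in place of 4-fluorophenyl on an aromatic carbon. Going by the values given here, no measured step exchanges the whole ring; the steps at hand only vary substituents on the phenyl. Compound 1 and compound 3 indicate that the unsubstituted and the fluoro-bearing six-membered ring are read alike, so a smaller five-membered aromatic ring is expected to stay near that level, with some allowance for loss. Compound 4 is therefore estimated at 0.2 nM (range 0.05 nM to 1 nM), a step of a 1.8-fold higher number from compound 3 to compound 4 (0.26 log units; within the scatter) expected to lie within the scatter.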

Compound 4, inhibition constant: 0.31 nM
The estimate for compound 4 lay 1.6-fold (0.19 log units) below the measured number; the range from low to high includes it.
By their numbers in this assay, from the lowest: compounds 1 and 3 (each within the scatter of the next); then compound 4; then compound 2.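

Replacing the whole ring at this position registers in this assay where the fluoro on the phenyl did not: a 2.8-fold higher number from compound 1 to compound 4 (0.45 log units; beyond the scatter) and a 2.8-fold higher number from compound 3 to compound 4 (0.45 log units; beyond the scatter), so thiophen-2-yl is read apart from both six-membered rings. The same compound stays ahead of the ortho-substituted comparator's level, with a 3.5-fold lower number from compound 2 to compound 4 (0.55 log units; beyond the scatter), which places the thiophen-2-yl between the 2-methylphenyl and the two rings that read alike. The data at hand offer no explanation for this placing.

Open, going by these compounds, is whether the step follows ring size or the hetero atom, a question that a furan-2-yl or thiophen-3-yl group at this position would address. Also open, on these data alone, is how an amine or a carboxylic acid on the distal ring would read in this assay.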